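Nitrooxy in Place of Bromo: an Expected Inhibition

The source may hold more compounds than are shown below. What is called first, only, known or untested is meant among the compounds shown, and "the series" means these compounds.

Compound 1 `Nc1ccc(C(=O)/C=C/c2ccc(Cl)cc2)cc1` gives 60% in a functional assay on the whole organism (strain albino) for inhibition, with Rattus norvegicus as the target, read by paw edema, with stated times of 30 min and 3 h, at a dose of 100 mg/kg by the oral route; on this read-out lower numbers stand for less inhibition and higher numbers for more inhibition at the one dose given (going by the name of the read-out). Compound 2 `CC(Br)C(=O)Nc1ccc(C(=O)/C=C/c2ccc(Cl)cc2)cc1` gives 59%.

Compound 2 sits alongside compound 1, since a number 1 percentage points lower from compound 1 to compound 2 (within the scatter) is within the scatter. Compound 3 `CC(O[N+](=O)[O-])C(=O)Nc1ccc(C(=O)/C=C/c2ccc(Cl)cc2)cc1` differs from compound 2 in that (nitrooxy in place of bromo on a saturated chain carbon bound to a carbonyl carbon and a saturated chain carbon). Among the measured compounds shown here, the one measured step, a number 1 percentage points lower from compound 1 to compound 2 (within the scatter), concerns a different point of the same arm and stayed within the scatter, and no measured step bears directly on the bromo-to-nitrooxy exchange. A step of about a number 1 percentage points lower from compound 2 to compound 3 (within the scatter) is therefore expected, none beyond the scatter. Compound 3 is estimated at 58%, with a range from 40% to 72%.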

Compound 3, a percentage reported as inhibition, in the whole organism at one dose (the size of the read-out at that dose, not a potency): 62%
Estimate against measurement, compound 3: 4 percentage points below; low and high end bracket the measured number.
By their numbers in this assay, from the lowest: compounds 2, 1 and 3 (each within the scatter of the next).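

In this assay, nitrooxy on this saturated chain carbon reads like bromo, with (a number 3 percentage points higher from compound 2 to compound 3 (within the scatter)) inside the scatter. The whole group set in place of a hydrogen atom on the nitrogen also stays inside the scatter, with (a number 2 percentage points higher from compound 1 to compound 3 (within the scatter)), so at this one dose neither change separates the compounds. No evidence is available that would explain this result. On these data alone, whether an amine or a carboxylic acid on this carbon would also stay inside the scatter remains open. So does the effect of a longer chain in place of the 1-(nitrooxy)ethyl group.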